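Working notes: from compound 2 to compound 3

This account rests on a few compounds, and the source may have more. Where it says the series, first, only, none or still open, it means among the compounds named here.

In a functional assay on L1210 cells (Mus musculus) for inhibition (a higher number here means a weaker inhibitor, a lower number a stronger inhibitor), compound 1 (`CC(C)CN(CC(=O)N(CC(C)C)NC(=O)OCc1ccccc1)/N=C/c1ccccc1B(O)O`) gives 16200 nM and compound 2 (`CC(C)CN(NC(=O)OCc1ccccc1)C(=O)CN(Cc1ccccc1)/N=C/c1ccccc1B(O)O`) gives 27900 nM on the same read-out. Compound 2 thus stands within the scatter of compound 1 and the two are not ranked. Compound 3 (`CC(C)CN(NC(=O)OCc1ccccc1)C(=O)CN(Cc1ccccc1)/N=C/c1cccc(B(O)O)c1`) differs from compound 2 on a carbon with a double bond to nitrogen, where the change is a group of 9 heavy atoms (6 carbon, 1 boron, 2 oxygen; one six-membered aromatic ring of carbon only) in place of a group of 9 heavy atoms (6 carbon, 1 boron, 2 oxygen; one six-membered aromatic ring of carbon only), on a carbon with a double bond to nitrogen with the same atoms in both, joined differently. Among the measured compounds shown here, the only measured step is a 1.7-fold higher number from compound 1 to compound 2 (0.24 log units; within the scatter) for phenyl in place of isopropyl elsewhere in the structure, and no measured pair tests the present change. For the measured compounds named here, with only that step as a guide, no shift beyond the scatter is expected in this assay and no direction can be argued. The estimated step is a 1.1-fold higher number from compound 2 to compound 3 (0.03 log units; within the scatter) and it remains uncertain. For compound 3 the expected value is 30000 nM within an estimated range from 12000 nM to 80000 nM on this read-out.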

Compound 3, half-maximal inhibitory concentration: 16200 nM
Beside the measured number, compound 3's estimate is 1.9-fold (0.27 log units) above it; the measured number falls inside the stated range.
By their numbers in this assay, from the lowest: compounds 1, 3 and 2 (each within the scatter of the next).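

In this assay the two arrangements of the same atoms on a carbon with a double bond to nitrogen give a 1.7-fold lower number from compound 2 to compound 3 (0.24 log units; within the scatter) and so are not ranked. Among the compounds shown here, this is the first measured pair at this position, where the earlier step concerned another part of the structure. It shows that joining the group of 9 heavy atoms differently, with its one six-membered aromatic ring of carbon only and its hydrogen-bond donor and acceptor counts unchanged, produces no shift that can be read in this series. No evidence bearing on this result is available. The compounds shown leave open whether the same rearrangement would read alike on the core of compound 1. They also leave open whether a carboxylic acid or an amine in place of the boron and its two oxygens would keep a value within the scatter of compound 2 and compound 3.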